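This account rests on a few compounds, and the source may have more. Where it says the series, first, only, none or still open, it means among the compounds named here.

Going by the values given here, compound 2 `CC(C)CCn1ccc(-c2ccc(Oc3ccccc3)cc2)c(C#N)c1=O` gives the lowest of the two numbers measured so far in a functional assay on CHO cells for positive allosteric modulation of metabotropic glutamate receptor 2 (Homo sapiens), read by scintillation counting and GTPgammaS binding, with a stated time of 30 min; a higher number here means that more compound is needed for the effect, a lower number that less compound is needed: compound 2 gives 42 nM, while compound 1 `CC(C)CCn1ccc(-c2ccc(OCC3CC3)cc2)c(C#N)c1=O` gives 290 nM. Among the compounds with values here, the only step between measured compounds is a 6.9-fold lower number from compound 1 to compound 2 (0.84 log units; beyond the scatter), which swaps the whole group that hangs from the oxygen on the aromatic ring.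

Compound 3 `CC(C)CCn1ccc(-c2ccc(Oc3cccnc3)cc2)c(C#N)c1=O` is the next compound on this path. It differs from compound 2 by pyridin-3-yl in place of phenyl on an oxygen on an aromatic ring. Within the data shown here, that is a much smaller change than the step already measured: the ring stays six-membered and aromatic, and only one ring atom changes. Among the measured compounds shown here, no measured step bears directly on this kind of change, so nothing here points to a clear direction.

The step from compound 2 to compound 3 is therefore expected to be small, within or just beyond the usual scatter, as a 1.7-fold higher number from compound 2 to compound 3 (0.22 log units; within the scatter). For compound 3 the estimated value in this assay is 70 nM, with an expected range from 25 nM to 250 nM.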

Compound 3, half-maximal effective concentration: 479 nM
The estimate for compound 3 lay 6.8-fold (0.84 log units) below the measured number; the whole stated range lies below it.
By their numbers in this assay, from the lowest: compound 2; then compounds 1 and 3 (each within the scatter of the next).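

Within this assay, exchanging one ring carbon of the phenyl for a nitrogen gives an 11-fold higher number from compound 2 to compound 3 (1.06 log units; beyond the scatter) and counts as a large step, even though the group keeps the same count of six heavy atoms and stays a six-membered aromatic ring. So this place on the oxygen does not treat two closely matched aromatic rings alike, and among the three groups seen here phenyl alone gives a number clearly separated from the other two, since the comparison of the remaining pair reads a 1.7-fold higher number from compound 1 to compound 3 (0.22 log units; within the scatter) and so does not tell pyridin-3-yl and cyclopropylmethyl apart. No measurement at hand accounts for the size of this step.

Going by these compounds, it remains open whether the nitrogen matters wherever it stands in the ring, since pyridin-4-yl and pyridin-2-yl on the same oxygen would test exactly that. On these data alone, it is equally open whether a phenyl carrying a fluorine or a methoxy group would keep, lower or raise the number, and whether the large step from phenyl to pyridin-3-yl would recur on a different group on the ring nitrogen of the shared core.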